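Permeability of an aryl ether variant of compound 2

The source may hold more compounds than are shown below. What is called first, only, known or untested is meant among the compounds shown, and "the series" means these compounds.

Compound 1 `COc1cccc(Oc2ccc3c(NCCCNCc4ccco4)ccnc3c2)c1`: 317 10^-6 cm/s
Compound 2 `COc1ccc(-c2ccc3c(NCCCNCc4ccco4)ccnc3c2)cc1`: 237 10^-6 cm/s

Among the measured compounds shown here, in an ADME assay for permeability, using PAMPA, with a stated time of 30 min, at pH 7.4 (on this read-out higher numbers stand for higher permeability and lower numbers for lower permeability), compound 2 gives 237 10^-6 cm/s; the only other number belongs to compound 1, and the two are separated by a 1.3-fold lower number from compound 1 to compound 2 (0.13 log units; within the scatter), so they stand together rather than apart. Compound 3 `COc1ccc(Oc2ccc3c(NCCCNCc4ccco4)ccnc3c2)cc1` differs from compound 2 by 4-methoxyphenoxy in place of 4-methoxyphenyl on an aromatic carbon. For the measured compounds named here, the one measured step that bears on this change is a 1.3-fold lower number from compound 1 to compound 2 (0.13 log units; within the scatter), where a methoxyphenoxy group gave way to a methoxyphenyl group without moving beyond the scatter; the change to compound 3 runs in the opposite sense, from a directly bound ring back to an aryl ether, with the methoxy group staying in place. On that basis compound 3 is expected to show no step beyond the scatter in this assay, the estimated step being a 1.2-fold higher number from compound 2 to compound 3 (0.07 log units; within the scatter). Compound 3 is therefore estimated at 280 10^-6 cm/s, within a range of 150 10^-6 cm/s to 500 10^-6 cm/s.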

Compound 3, apparent permeability: 317 10^-6 cm/s
Compound 3: the middle estimate sits 1.1-fold (0.05 log units) below what was measured, and the stated range covers the measured number.
By their numbers in this assay, from the lowest: compounds 2, 1 and 3 (each within the scatter of the next).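

In this assay, the step of a 1.3-fold higher number from compound 2 to compound 3 (0.13 log units; within the scatter) stays within the scatter, so on this aromatic carbon 4-methoxyphenoxy and 4-methoxyphenyl cannot be told apart by this read-out. Among the compounds shown here, the step of no change at the digits printed from compound 1 to compound 3 (within the scatter) adds a comparison that the earlier compounds did not offer: with the oxygen on the aromatic ring kept, 4-methoxyphenyl in place of 3-methoxyphenyl leaves the printed number unchanged. Nothing available explains why these three compounds fall so close together.

The compounds shown all carry a methoxy-substituted aromatic ring at this place, so they leave open whether that ring matters at all. A carboxylic acid, an amine or a longer alkyl chain on the same aromatic carbon could give a step beyond the scatter in this assay, or none.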